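Acylthiosemicarbazide series: aryl swap on the carbonyl carbon

This account rests on a few compounds, and the source may have more. Where it says the series, first, only, none or still open, it means among the compounds named here.

Compound 2 `COc1cc2ncnc(NNC(=S)NC(=O)c3ccccc3OC)c2cc1OC` is the point of departure. In a functional assay on KB cells (Homo sapiens) for cytotoxicity, read by MTT assay, with a stated time of 72 h (a lower number here means a stronger inhibitor, a higher number a weaker inhibitor), compound 2 gives 3850 nM. Among the compounds with values here, its only measured neighbour is compound 1 `COc1cc2ncnc(NNC(=S)NC(=O)c3ccc(Cl)cc3)c2cc1OC`, which in this assay gives 4590 nM; the two numbers lie within the scatter of each other, so neither can be set apart from the other.

Compound 3 `COc1cc2ncnc(NNC(=S)NC(=O)c3ccc(C)cc3)c2cc1OC` is not yet measured. It differs from compound 2 at one place: 4-methylphenyl in place of 2-methoxyphenyl on a carbonyl carbon. Within the data shown here, the only measured step that bears on this kind of change is a 1.2-fold lower number from compound 1 to compound 2 (0.08 log units; within the scatter), which also exchanges one aryl group for another on the carbonyl carbon whose other neighbour is an amide-type nitrogen, and that exchange did not move the number beyond the scatter. On this basis the step to compound 3 is expected to stay within the scatter as well, with no direction to be read from the two values shown; the expected step is a 1.0-fold higher number from compound 2 to compound 3 (0.02 log units; within the scatter). For compound 3 in this assay the estimate is therefore 4000 nM, with a range from 2000 nM to 8000 nM. Any larger movement would need more compounds than these two to support it.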

Compound 3, half-maximal inhibitory concentration: 24200 nM
Estimate against measurement, compound 3: 6.1-fold (0.78 log units) below, outside the stated range (above it).
By their numbers in this assay, from the lowest: compounds 2 and 1 (each within the scatter of the next); then compound 3.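

The aryl group on the carbonyl carbon is not indifferent in this assay: replacing 2-methoxyphenyl with 4-methylphenyl weakens the compound (a 6.3-fold higher number from compound 2 to compound 3 (0.80 log units; beyond the scatter)), and so does methyl in place of chloro on an aromatic carbon (a 5.3-fold higher number from compound 1 to compound 3 (0.72 log units; beyond the scatter)). The earlier pair gave no sign of this sensitivity, since 4-chlorophenyl and 2-methoxyphenyl could not be set apart; among these three compounds, 4-methylphenyl alone separates from the others, so the position tolerates some aryl groups but not every one. Nothing shown here bears on the reason for this shift.

Three compounds cannot show whether the loss belongs to methyl itself or to the absence of the chloro and methoxy groups, because compound 3 is the only one carrying an alkyl substituent and the step from compound 2 changes the aryl substitution as a whole. Also open, going by these compounds, is how the number responds when that aromatic carbon carries a fluoro, a trifluoromethyl, an amine or a carboxylic acid, or when a longer chain such as ethyl replaces the methyl.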